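This account rests on a few compounds, and the source may have more. Where it says the series, first, only, none or still open, it means among the compounds named here.

Measured so far:
- compound 1 `Cc1ccc(-c2cc(C(=O)Nc3ccc(Cl)nc3Cl)nn2-c2ccc3ccccc3n2)cc1` — 12700 nM in a functional assay on MCF7 cells (Homo sapiens) for cytotoxicity, read by sulforhodamine B assay, with a stated time of 72 h; a lower number here means a stronger inhibitor, a higher number a weaker inhibitor
- compound 2 `Cc1ccc(-c2cc(C(=O)Nc3ccnc(Cl)c3)nn2-c2ccc3ccccc3n2)cc1` — 3300 nM
- compound 3 `COc1ncccc1NC(=O)c1cc(-c2ccc(C)cc2)n(-c2ccc3ccccc3n2)n1` — 30200 nM

Compound 2 holds the lowest number of the three in this assay. Its nearest neighbour is compound 1, and the gap is a 3.8-fold lower number from compound 1 to compound 2 (0.59 log units; beyond the scatter); the widest gap is to compound 3, at a 9.2-fold higher number from compound 2 to compound 3 (0.96 log units; beyond the scatter). Compound 1 and compound 3 differ by a 2.4-fold higher number from compound 1 to compound 3 (0.38 log units; beyond the scatter).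

Compound 4 `Cc1ccc(-c2cc(C(=O)NCc3cccnc3)nn2-c2ccc3ccccc3n2)cc1` has not yet been measured. Relative to compound 2 the change is (pyridin-3-yl)methyl in place of 2-chloropyridin-4-yl on an amide-type nitrogen.

Each of the three measured steps exchanges one pyridinyl group for another on the amide-type nitrogen, and those exchanges already move the number by the amounts above. Within the data shown here, none of them puts a (pyridin-3-yl)methyl group there, so no measured step tracks this change closely. What the series does show is that every alteration of the group on the amide-type nitrogen so far has moved the number, and that compound 2 sits at the low end, so the step is more likely to go up than down.

The estimate for compound 4 is therefore a higher number, 10000 nM, with an expected range of 3000 nM to 35000 nM. The expected step from compound 2 is a 3.0-fold higher number from compound 2 to compound 4 (0.48 log units; beyond the scatter).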

Compound 4, half-maximal inhibitory concentration: 19000 nM
Compound 4: the middle estimate sits 1.9-fold (0.28 log units) below what was measured, within the range that was stated.
By their numbers in this assay, from the lowest: compound 2; then compounds 1, 4 and 3 (each within the scatter of the next, the first and the last beyond it).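

Replacing 2-chloropyridin-4-yl with (pyridin-3-yl)methyl on the amide-type nitrogen of compound 2 keeps the heavy-atom, donor and acceptor counts unchanged, yet in this assay it gives a 5.8-fold higher number from compound 2 to compound 4 (0.76 log units; beyond the scatter), so these counts alone do not preserve the low number of compound 2. Among these compounds, with the first group at this position to carry a methyl link to its ring and no chlorine or methoxy substituent, the number cannot be told apart from those of the substituted pyridinyl amides, at a 1.5-fold higher number from compound 1 to compound 4 (0.17 log units; within the scatter) and a 1.6-fold lower number from compound 3 to compound 4 (0.20 log units; within the scatter), which leaves compound 2 as the only one of the four beyond the scatter of all the others. No available evidence accounts for this step.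

Because compound 4 differs from compound 2 in the methyl link, the ring attachment point and the chlorine at once, the share of each in the step remains unresolved. A (2-chloropyridin-4-yl)methyl group or an unsubstituted pyridin-4-yl group on the same nitrogen would separate these contributions.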